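The compounds below may be only part of what the source reports. "The series", "measured", "known", "first", "only" and "open" are said of these compounds alone.

Measured in a functional assay on M21 cells (Homo sapiens) for antiproliferative activity, read by sulforhodamine B assay, with a stated time of 48 h; on this read-out lower numbers stand for stronger inhibition and higher numbers for weaker inhibition:

- Compound 1 `CCc1ccccc1NS(=O)(=O)c1ccc(N2CCNC2=O)cc1`: 180 nM
- Compound 2 `O=C1NCCN1c1ccc(S(=O)(=O)Nc2ccc(C3CCCCC3)cc2)cc1`: > 1000 nM (a limit of the assay)
- Compound 3 `O=C1NCCN1c1ccc(S(=O)(=O)Nc2ccc(F)cc2)cc1`: 230 nM

Compound 3 gives 230 nM in this assay. This value lies within the scatter of the value of compound 1, as the step of a 1.3-fold higher number from compound 1 to compound 3 (0.11 log units; within the scatter) shows. Compound 2 reached only a limit, so no exact number exists for it.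

Compound 4 `CCCCCCCc1ccc(NS(=O)(=O)c2ccc(N3CCNC3=O)cc2)cc1` is compound 3 with heptyl in place of fluoro on an aromatic carbon, para to a large group (heptyl in place of fluoro on an aromatic carbon).

The most relevant measured change is an at least 4.3-fold lower number from compound 2 to compound 3 (0.63 log units; beyond the scatter), which is beyond the scatter. There, fluoro replaces cyclohexyl, so going back from fluoro to a large carbon group would be expected to raise the number. The step of a 1.3-fold higher number from compound 1 to compound 3 (0.11 log units; within the scatter) offers less guidance, since it exchanges whole groups on the sulfonamide nitrogen and stays within the scatter. This expectation rests on compound 2 alone, and its size is open because that compound gave only a limit.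

The expected change is a 6.5-fold higher number from compound 3 to compound 4 (0.81 log units; beyond the scatter), a rise beyond the scatter. For compound 4 the estimated value is 1500 nM. The expected range for compound 4 runs from 500 nM to 6000 nM.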

Compound 4, half-maximal inhibitory concentration: > 1000 nM
Compound 4: no number, only a limit; the forecaster's own chance of this, stated with the estimate: 60%; the middle value lies beyond the limit too.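

In this assay, heptyl in place of fluoro on this aromatic carbon, para to a large group, gives an at least 4.3-fold higher number from compound 3 to compound 4 (0.63 log units; beyond the scatter), a shift toward weaker inhibition. Until now, the case against a large carbon group here rested on cyclohexyl in compound 2 alone; heptyl, which carries no ring, now points the same way, so the weaker result is not tied to cyclohexyl. The two large groups cannot be ranked against each other, and the step between compound 2 and compound 4 cannot be read, as both values are limits of the assay and not numbers: the limit of > 1000 nM in this assay, at which 2 of the 4 values shown sit.

As far as these compounds go, how far compound 4 lies past its limit stays open, and so does the chain length at which the number starts to rise, since nothing between fluoro and heptyl stands at this place. From the compounds shown here alone, it is also open whether a short chain such as propyl, or a methoxy, an amine or a carboxylic acid on this carbon, would stay within the scatter of compound 3 at 230 nM or move away from it.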